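This account rests on a few compounds, and the source may have more. Where it says the series, first, only, none or still open, it means among the compounds named here.

Measured so far:
- compound 1 `COc1cc(NC(=O)c2ccc(C#N)cc2)ccc1NS(=O)(=O)C(F)(F)F`; in an ADME assay on HEK293 cells (Homo sapiens) for cytotoxicity, read by MTT assay, with a stated time of 48 h (on this read-out higher numbers stand for weaker inhibition and lower numbers for stronger inhibition), compound 1 gives > 250000 nM, which is a limit of the assay and not a number.
- compound 2 `CCS(=O)(=O)Nc1ccc(NC(=O)c2ccc(C#N)cc2)cc1Cl`; in this assay compound 2 gives > 250000 nM, again a limit of the assay and not a number.

Compound 2 therefore stands on a limit only. Among the measured compounds shown here, the one further value shown, that of compound 1, is also a limit, so the two values cannot be ordered against each other and show no difference beyond the scatter (the limit of > 250000 nM in this assay, at which 2 of the 2 values shown sit).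

Compound 3 `N#Cc1ccc(C(=O)Nc2ccc(NS(=O)(=O)C(F)(F)F)c(Cl)c2)cc1` is not yet measured in this assay. Its difference from compound 2 is trifluoromethyl in place of ethyl on a sulfonyl sulfur, the sulfonamide nitrogen and the rest of the shared core unchanged. For the measured compounds named here, no step between measured compounds is available to set a size for this change; both values shown sit at the limit (the limit of > 250000 nM in this assay, at which 2 of the 2 values shown sit), so no direction can be read from them.

The step that the limit leaves unreadable from compound 2 to compound 3 is expected to be none beyond the scatter. Compound 3 is expected to come in at 300000 nM, with a range of 120000 nM to 800000 nM, most likely reported again only as a limit.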

Compound 3, half-maximal inhibitory concentration: > 250000 nM
Compound 3 gave a limit, no number; the forecaster's own chance of this, stated with the estimate: 85%; the middle value does not contradict the limit.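

No new step can be read among compound 1, compound 2 and compound 3 in this assay, since each stands only on a limit of the assay: the limit of > 250000 nM in this assay, at which 3 of the 3 values shown sit.

The compounds shown leave open whether trifluoromethyl in place of ethyl on a sulfonyl sulfur, or chloro in place of methoxy on an aromatic carbon, changes this read-out at all.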